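Urea series: bromo for tert-butyl on the aryl ring

The source may hold more compounds than are shown below. What is called first, only, known or untested is meant among the compounds shown, and "the series" means these compounds.

Measured so far in an ADME assay on the whole organism with Oryza sativa as the target, tested at 0.1 uM; a lower number here means a stronger effect, a higher number a weaker effect of the compound at the concentration tested:
compound 1, `C[C@@H](NC(=O)Nc1ccccc1C(C)(C)C)c1ccccc1`, 100%
compound 2, `C[C@H](NC(=O)Nc1ccccc1C(C)(C)C)c1ccccc1`, 101%
compound 3, `C[C@@H](NC(=O)Nc1cccc(C(F)(F)F)c1)c1ccccc1`, 82%

Compound 1 stands second highest of the three numbers. Its nearest neighbour is compound 2, the step being a number 1 percentage points higher from compound 1 to compound 2 (within the scatter); the two compounds differ only in configuration as drawn, so that step is read as a null result (the fact that compounds 1 and 2 differ only in the configuration as drawn). Among the compounds with values here, compound 3 is furthest away, its value lying beyond the scatter from that of compound 1, but it differs from compound 1 in more than one place and no single step connects them.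

Compound 4, `C[C@@H](NC(=O)Nc1ccccc1Br)c1ccccc1`, has not yet been measured. The change from compound 1 is bromo in place of tert-butyl on an aromatic carbon, ortho to a large group. Within the data shown here, none of the measured steps exchanges one group for another at this position; the only measured step is the configurational one, which was within the scatter and says nothing about substituent changes on the ring. The expectation for compound 4 in this assay therefore rests on little, and the estimated step is a number 7 percentage points lower from compound 1 to compound 4 (within the scatter), with no confident direction. Compound 4 is expected to give about 93%, within the range 70% to 110%.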

Compound 4, a percentage reported as activity, at one concentration (the size of the read-out at that concentration, not a potency): 99%
Compound 4: the middle estimate sits 6 percentage points below what was measured; the measured number falls inside the stated range.
By their numbers in this assay, from the lowest: compound 3; then compounds 4, 1 and 2 (each within the scatter of the next).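

In this assay, bromo in place of tert-butyl on an aromatic carbon, ortho to a large group, gives a number 1 percentage points lower from compound 1 to compound 4 (within the scatter), so this position now has a measured exchange of one group for another and not only a change of configuration. The group leaving has 4 heavy atoms and the one entering has 1, and this difference in count leaves the two numbers within the scatter of each other. Nothing at hand gives a cause for this result.

Going by these compounds, whether an amine or a carboxylic acid on this same aromatic carbon would give a number beyond the scatter of compound 1 remains open. Also open, on these data alone, is whether configuration stays without visible consequence when bromo replaces tert-butyl.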